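A few compounds are considered here, and "the series" means these few. Any claim that something is new, unique, unknown or untested is made for them only; others in the source may bear on it.

Measured compounds:
- compound 1 `CN(C)CCn1cnnc1-c1cc(Oc2ccc(NC(=O)N/N=C/c3c(Cl)cccc3Cl)cc2F)ccn1`: 280 nM
- compound 2 `COc1ccc(OC)c(/C=N/NC(=O)Nc2ccc(Oc3ccnc(-c4nncn4CCN(C)C)c3)c(F)c2)c1`: 2070 nM
- compound 3 `COc1ccc(/C=N/NC(=O)Nc2ccc(Oc3ccnc(-c4nncn4CCN(C)C)c3)c(F)c2)c(OC)c1`: 1780 nM

These three compounds were tested in a functional assay on HT-29 cells (Homo sapiens) for cytotoxicity, read by MTT assay, with a stated time of 72 h; on this read-out higher numbers stand for weaker inhibition and lower numbers for stronger inhibition. Compound 3 stands second highest of the three numbers; its nearest neighbour is compound 2, and the two lie within the scatter of each other, as a 1.2-fold lower number from compound 2 to compound 3 (0.07 log units; within the scatter) shows. Compound 1 sits well apart, and the change from compound 1 to compound 3 gave a 6.4-fold higher number from compound 1 to compound 3 (0.80 log units; beyond the scatter), much as a 7.4-fold higher number from compound 1 to compound 2 (0.87 log units; beyond the scatter) did.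

Compound 4 `COc1ccc(/C=N/NC(=O)Nc2ccc(Oc3ccnc(-c4nncn4CCN(C)C)c3)c(F)c2)c(OC)c1OC` differs from compound 3 by methoxy in place of hydrogen on an aromatic carbon. Going by the values given here, no measured step adds a methoxy group in this way. Among the compounds with values here, the one step that moves a methoxy group between aromatic carbons, a 1.2-fold lower number from compound 2 to compound 3 (0.07 log units; within the scatter), stayed within the scatter, while the dimethoxyphenyl compounds as a group gave weaker inhibition than compound 1. On that footing the third methoxy is expected to leave the number close to that of compound 3, with any shift small and not beyond the scatter, which is a 1.2-fold higher number from compound 3 to compound 4 (0.09 log units; within the scatter). The estimate for compound 4 in this assay is 2200 nM, with a range from 900 nM to 5500 nM.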

Compound 4, half-maximal inhibitory concentration: 3970 nM
Compound 4: the middle estimate sits 1.8-fold (0.26 log units) below what was measured; low and high end bracket the measured number.
By their numbers in this assay, from the lowest: compound 1; then compounds 3, 2 and 4 (each within the scatter of the next, the first and the last beyond it).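

In this assay the third methoxy, ortho to two methoxy groups, gave a 2.2-fold higher number from compound 3 to compound 4 (0.35 log units; beyond the scatter) and so, unlike the earlier move of a methoxy group between aromatic carbons, adding one at this carbon shifted the number beyond the scatter. The comparison of the 2,3,4-trimethoxyphenyl and 2,5-dimethoxyphenyl compounds stays within the scatter at a 1.9-fold higher number from compound 2 to compound 4 (0.28 log units; within the scatter) while the comparison with the 2,6-dichlorophenyl compound widens to a 14-fold higher number from compound 1 to compound 4 (1.15 log units; beyond the scatter) and is large. Nothing measured here accounts for these differences.

Open, on these data alone, is whether a single chlorine or a 2,6-dimethoxyphenyl group would stand nearer compound 1 or nearer the methoxy compounds. Also open, as far as these compounds go, is how a hydroxy group or an amine at this aromatic carbon would compare with the methoxy of compound 4.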